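Phenethyl in place of the aryl at the ortho position

This account rests on a few compounds, and the source may have more. Where it says the series, first, only, none or still open, it means among the compounds named here.

Among the compounds with values here, compound 3 `Cc1ccc(-c2cc(Cl)cc(Cl)c2/C=C/[C@@H]2C[C@@H](O)CC(=O)O2)cc1` stands at the high end of the three numbers so far: in an assay for inhibition of 3-hydroxy-3-methylglutaryl-coenzyme A reductase (Rattus norvegicus) (a higher number here means a weaker inhibitor, a lower number a stronger inhibitor), compound 3 gives 190 nM. Compound 1 `O=C1C[C@H](O)C[C@@H](/C=C/c2c(Cl)cc(Cl)cc2-c2cc(Cl)cc(Cl)c2)O1` gives 37 nM in this assay, and compound 2 `Cc1cc(-c2cc(Cl)cc(Cl)c2/C=C/[C@@H]2C[C@@H](O)CC(=O)O2)ccc1F` gives 29 nM. The two steps onto compound 3 both go the same way: a 5.1-fold higher number from compound 1 to compound 3 (0.71 log units; beyond the scatter) and a 6.6-fold higher number from compound 2 to compound 3 (0.82 log units; beyond the scatter). The step of a 1.3-fold lower number from compound 1 to compound 2 (0.11 log units; within the scatter) lies within the scatter.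

Compound 4 `O=C1C[C@H](O)C[C@@H](/C=C/c2c(Cl)cc(Cl)cc2CCc2ccccc2)O1` is not yet measured. It differs from compound 3 in one place: phenethyl in place of 4-methylphenyl on an aromatic carbon. Within the data shown here, no measured step involves a phenethyl at this position; the three measured compounds carry only directly attached aromatic rings there, so the measured steps bear on the change only in showing that this position tolerates different groups with modest shifts. Compound 3 already sits at the weak end of the series, and a further shift in either direction of similar size is plausible. The expected step of a 1.3-fold higher number from compound 3 to compound 4 (0.12 log units; within the scatter) is therefore set near nothing beyond the scatter, with a wide range. For compound 4 the estimate in this assay is 250 nM, expected between 60 nM and 1000 nM.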

Compound 4, half-maximal inhibitory concentration: 430 nM
Beside the measured number, compound 4's estimate is 1.7-fold (0.24 log units) below it, within the range that was stated.
By their numbers in this assay, from the lowest: compounds 2 and 1 (each within the scatter of the next); then compound 3; then compound 4.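

In this assay, phenethyl on this aromatic carbon gives a higher number than each directly attached aromatic ring among the compounds shown: a 2.3-fold higher number from compound 3 to compound 4 (0.35 log units; beyond the scatter), a 15-fold higher number from compound 2 to compound 4 (1.17 log units; beyond the scatter) and a 12-fold higher number from compound 1 to compound 4 (1.07 log units; beyond the scatter). The position therefore tolerates a change from 4-methylphenyl to phenethyl with only a modest step, but the steps from 4-fluoro-3-methylphenyl and 3,5-dichlorophenyl are large, and compound 4 is the weakest inhibitor of the four. No supporting data bear on why the number rises with phenethyl at this position.

The compounds shown do not separate the effect of the chain from that of the ring substitution, as phenethyl carries an unsubstituted ring while the two strongest compounds carry substituted rings. A 3,5-dichlorophenethyl or 4-fluoro-3-methylphenethyl group would test the chain with those ring substituents kept, while a directly attached unsubstituted phenyl, a benzyl or a 3-phenylpropyl chain would show how the number follows the link between the two rings.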